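The source may hold more compounds than are shown below. What is called first, only, known or untested is meant among the compounds shown, and "the series" means these compounds.

Of the compounds shown here, two have been measured so far in an assay on isolated protein for inhibition of Rho-associated protein kinase 2 (Homo sapiens), read by radiometric assay and 33P incorporation, with a stated time of 40 min, in the presence of a further agent that is not named here; a higher number here means a weaker inhibitor, a lower number a stronger inhibitor. Compound 1, with the structure `COc1cccc(CN2CCc3cc(-c4ccc5[nH]ncc5c4)ccc3C2=O)c1`, gives 632 nM. Compound 2, with the structure `COc1cccc(Cn2cnc3sc(-c4ccc5[nH]ncc5c4)cc3c2=O)c1`, gives 2 nM. On these two numbers compound 2 stands at the lower end: its value lies well below that of compound 1, a gap far wider than the usual scatter of this assay, so compound 2 is clearly the stronger inhibitor of the pair.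

Compound 3, with the structure `COc1cccc(Cn2cnc3sc(-c4ccncc4)cc3c2=O)c1`, has not yet been measured. It differs from compound 2 in one place: pyridin-4-yl in place of 1H-indazol-5-yl on an aromatic carbon. The group that leaves carries a hydrogen-bond donor as well as an acceptor; the group that enters keeps an acceptor but has no donor, and it is smaller. Among the measured compounds shown here, no measured pair in this set shows the effect of such a swap, so the expectation rests on compound 2 alone. A step toward weaker inhibition beyond the scatter is expected, of moderate size, as a 15-fold higher number from compound 2 to compound 3 (1.18 log units; beyond the scatter) expresses. Compound 3 is therefore estimated at 30 nM, with a likely range from 5 nM to 200 nM.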

Compound 3, half-maximal inhibitory concentration: 6 nM
Beside the measured number, compound 3's estimate is 5.0-fold (0.70 log units) above it; the measured number falls inside the stated range.
By their numbers in this assay, from the lowest: compound 2; then compound 3; then compound 1.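

In this assay, putting pyridin-4-yl in place of 1H-indazol-5-yl on the aromatic carbon next to the ring sulfur gives a 3.0-fold higher number from compound 2 to compound 3 (0.48 log units; beyond the scatter), a step that is modest but beyond the scatter. This shows that the position does not depend on the larger two-ring group: compound 3, with one six-membered aromatic ring and no hydrogen-bond donor in this group, still gives 6 nM. Among the compounds shown here, nothing measured here explains why the step is this small, and the single swap changes the group's size, its ring count and its donor count all at once, so these cannot be told apart.

The compounds shown leave open whether the ring nitrogen of the pyridin-4-yl group matters, which a plain phenyl group at this position would test, and whether an amine added to the pyridine ring would bring back the small loss seen here. They also leave open how far the position tolerates other kinds of group, such as a carboxylic acid on the ring or a non-aromatic group like morpholine in place of the pyridine.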